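Removing One Chloro from the Dichlorophenyl Aniline

The source may report more compounds than this note shows. Statements on the series, on what has been measured and on what is new or still open speak of the compounds shown alone.

compound 1, `CN1CCN(CCCOc2cccc3nc(Nc4ccc(Cl)c(F)c4)ccc23)CC1`: 1990 nM
compound 2, `CC(C)c1ccc(Nc2ccc3c(OCCCN4CCN(C)CC4)cccc3n2)cc1`: 15600 nM
compound 3, `CN1CCN(CCCOc2cccc3nc(Nc4cc(Cl)cc(Cl)c4)ccc23)CC1`: 1870 nM

In a functional assay on cells (Panel ovarian (Carcinoma cell lines), Homo sapiens) for inhibition, read by sulforhodamine B assay, with a stated time of 48 h (a higher number here means a weaker inhibitor of growth, a lower number a stronger inhibitor of growth), compound 3 gives 1870 nM, the lowest of the three numbers shown, though a 1.1-fold lower number from compound 1 to compound 3 (0.03 log units; within the scatter) leaves it within the scatter of compound 1; only compound 2 stands apart, an 8.3-fold lower number from compound 2 to compound 3 (0.92 log units; beyond the scatter). Compound 4 `CN1CCN(CCCOc2cccc3nc(Nc4cccc(Cl)c4)ccc23)CC1` differs from compound 3 by hydrogen in place of chloro on an aromatic carbon. For the measured compounds named here, no measured step removes a single chloro. The two steps beyond the scatter, a 7.8-fold higher number from compound 1 to compound 2 (0.89 log units; beyond the scatter) and an 8.3-fold lower number from compound 2 to compound 3 (0.92 log units; beyond the scatter), both involve the isopropyl of compound 2, while the halogen swap a 1.1-fold lower number from compound 1 to compound 3 (0.03 log units; within the scatter) changed little. Compound 4 is therefore expected to move only modestly, a 1.5-fold higher number from compound 3 to compound 4 (0.18 log units; within the scatter), toward a slightly higher number. The estimate for compound 4 is 2800 nM, with a range from 1200 nM to 7000 nM.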

Compound 4, concentration for 50% growth inhibition: 2010 nM
For compound 4 the middle estimate is 1.4-fold (0.14 log units) above the measured one; the range from low to high includes it.
By their numbers in this assay, from the lowest: compounds 3, 1 and 4 (each within the scatter of the next); then compound 2.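

In this assay, taking one chloro off the 3,5-dichlorophenyl leaves the number where it was (a 1.1-fold higher number from compound 3 to compound 4 (0.03 log units; within the scatter)), so at this aromatic carbon hydrogen serves as well as chloro. The 3-chlorophenyl of compound 4 also matches the 4-chloro-3-fluorophenyl (a 1.0-fold higher number from compound 1 to compound 4 (0.00 log units; within the scatter)) and stands well apart from the 4-isopropylphenyl (a 7.8-fold lower number from compound 2 to compound 4 (0.89 log units; beyond the scatter)), so one chloro is enough to keep compound 4 with compound 1 and compound 3. Nothing measured here explains this flatness.

Still open, from the compounds shown here alone, is whether a plain phenyl, or a methoxy or an amino group at this place, would stay with these three or fall toward compound 2.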